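Removing the carboxymethoxy from compound 2: expected clearance

The compounds below may be only part of what the source reports. "The series", "measured", "known", "first", "only" and "open" are said of these compounds alone.

Of the compounds shown here, three built on the same core have been measured in an ADME assay on microsomes from liver (Mus musculus) for metabolic stability, using NADPH, with a stated time of 60 min, in the presence of a further agent that is not named here; a lower number here means slower removal, a higher number faster removal of the compound. Compound 1 `CC(C)(Oc1ccc([C@H]2CC[C@]3(CC2)OOC2(O3)C3CC4CC(C3)CC2C4)cc1)C(=O)O` gives 7 mL.min-1.g-1. Compound 2 `O=C(O)COc1ccc([C@H]2CC[C@]3(CC2)OOC2(O3)C3CC4CC(C3)CC2C4)cc1C(=O)O` gives 8 mL.min-1.g-1, and compound 3 `O=C(O)COc1ccc([C@H]2CC[C@]3(CC2)OOC2(O3)C3CC4CC(C3)CC2C4)cc1Cl` gives 8 mL.min-1.g-1. Compound 2 stands level with compound 3, the two together being the highest of the three numbers, and its gap to compound 1 lies within the scatter, so all three read as one level.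

Compound 4 `O=C(O)c1cccc([C@H]2CC[C@]3(CC2)OOC2(O3)C3CC4CC(C3)CC2C4)c1` has not yet been measured. It differs from compound 2 in one place: hydrogen in place of carboxymethoxy on an aromatic carbon. Among the measured compounds shown here, the only measured step, no change at the digits printed from compound 2 to compound 3 (within the scatter), exchanges a different group and does not touch the carboxymethoxy, so no measured step bears directly on this change. Compounds 1 and 2 differ in more than one place, and their values are within the scatter of each other.

For the measured compounds named here, with no direct precedent, the expectation for compound 4 in this assay is a number near the shared level, with a widened range to cover the untested change: a 1.3-fold higher number from compound 2 to compound 4 (0.10 log units; within the scatter). Compound 4 is therefore estimated at 10 mL.min-1.g-1, between 5 mL.min-1.g-1 and 25 mL.min-1.g-1.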

Compound 4, intrinsic clearance in microsomes in the Mus musculus assay: 30 mL.min-1.g-1
Compound 4: middle estimate off by 3.0-fold (0.48 log units), on the low side, and the stated range ends below it.
By their numbers in the Mus musculus assay, from the lowest: compounds 1, 2 and 3 (each within the scatter of the next); then compound 4.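

In the Mus musculus assay, hydrogen in place of carboxymethoxy, on the aromatic carbon ortho to a carboxy group and para to a large group, gives a 3.8-fold higher number from compound 2 to compound 4 (0.57 log units; beyond the scatter). Among the compounds shown here, this is the first single change to move clearance beyond the scatter, unlike the one earlier step, no change at the digits printed from compound 2 to compound 3 (within the scatter). The same change also separates the two compounds in a second measurement, though only as a pair of limits: in a physicochemical assay for solubility, read by nephelometry, measured as kinetic solubility, with a stated time of 30 min, at pH 2.0 (a higher number here means a more soluble compound, a lower number a less soluble compound), compound 2 gives > 100 ug/mL, which is a limit of the assay and not a number, and the next sentence gives the other.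

In the physicochemical assay compound 4 gives < 1.6 ug/mL, also a limit of the assay and not a number.

The whole carboxymethoxy leaves in one step, so the compounds shown do not tell whether its ether oxygen or its carboxylic acid end carries the difference. As far as these compounds go, how a methoxy, a hydroxyl or a longer chain ending in an amine would read at this position remains open.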